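From one methyl to two on the aromatic ring

The source may hold more compounds than are shown below. What is called first, only, known or untested is meant among the compounds shown, and "the series" means these compounds.

Measured so far in a functional assay on KB cells (Homo sapiens) for cytotoxicity (a lower number here means that less compound is needed, a higher number that more compound is needed for the effect), for three compounds:
compound 1 `COC1=C(C)C(=O)/C(=C(O)/C=C/c2ccc(O)cc2)C(=O)C1(C)C` gives 3 ug/mL
compound 2 `COC1=C(C)C(=O)/C(=C(O)/C=C/c2ccc(F)cc2)C(=O)C1(C)C` gives 2.7 ug/mL
compound 3 `COC1=C(C)C(=O)/C(=C(O)/C=C/c2ccc(C)cc2)C(=O)C1(C)C` gives 1.9 ug/mL

Compound 3 gives 1.9 ug/mL and does not stand apart from the other two, as every gap among these three stays within the usual scatter. Compound 4 `COC1=C(C)C(=O)/C(=C(O)/C=C/c2cc(C)cc(C)c2)C(=O)C1(C)C` carries 3,5-dimethylphenyl in place of 4-methylphenyl on a double-bonded chain carbon bound to a double-bonded chain carbon and is still unmeasured.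

The closest evidence comes from swapping one group on that aromatic ring. The steps of a 1.1-fold lower number from compound 1 to compound 2 (0.05 log units; within the scatter) and a 1.6-fold lower number from compound 1 to compound 3 (0.20 log units; within the scatter) and also a 1.4-fold lower number from compound 2 to compound 3 (0.15 log units; within the scatter) all remained small. None of these compounds tests a second methyl, so that part of the change has no direct measurement. No step beyond the scatter is expected, and the data give no firm direction. The expected step is a 1.1-fold lower number from compound 3 to compound 4 (0.02 log units; within the scatter) and no more than that. For compound 4 the estimated value is 1.8 ug/mL with an expected range from 1 ug/mL to 3.4 ug/mL in this assay once measured.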

Compound 4, concentration for half-maximal effect: 1.6 ug/mL
For compound 4 the middle estimate is 1.1-fold (0.05 log units) above the measured one; the measured number falls inside the stated range.
By their numbers in this assay, from the lowest: compounds 4, 3, 2 and 1 (each within the scatter of the next).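

In this assay, replacing 4-methylphenyl with 3,5-dimethylphenyl adds a carbon to the group on the double-bonded chain carbon and adds no hydrogen-bond donors or acceptors, yet the step stays within the scatter (a 1.2-fold lower number from compound 3 to compound 4 (0.07 log units; within the scatter)). Going by these compounds alone, this is the first sign that the position tolerates a second methyl, and the other two new steps also stay within the scatter (a 1.7-fold lower number from compound 2 to compound 4 (0.23 log units; within the scatter) and a 1.9-fold lower number from compound 1 to compound 4 (0.27 log units; within the scatter)), so none of the four groups stands apart. No measured evidence is available to explain this flat picture.

The new group differs in both the number and the placement of its methyl groups, and the compounds shown cannot separate those two changes. On these data alone, it also remains open whether an amine, a carboxylic acid or a longer chain on this aromatic ring would produce a step beyond the scatter.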